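The compounds below may be only part of what the source reports. "The series", "measured", "known", "first", "only" and "open" are said of these compounds alone.

The measured compounds so far:
compound 1, `O=C(/C=C/c1ccc2c(c1)B(O)OC2)c1ccccc1`, giving 3400 nM
compound 2, `O=C(/C=C/c1ccc2c(c1)B(O)OC2)c1ccc(I)cc1`, giving 4200 nM

Both were tested in a functional assay on SK-OV-3 cells (Homo sapiens) for cytotoxicity, read by MTT assay, with a stated time of 48 h; a lower number here means a stronger inhibitor, a higher number a weaker inhibitor. Among the compounds with values here, compound 1 stands at the lowest of the two numbers, but its only neighbour, compound 2, lies close: the step of a 1.2-fold higher number from compound 1 to compound 2 (0.09 log units; within the scatter) is within the usual scatter, so the two compounds cannot be told apart on this evidence.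

The next compound, compound 3, `COCOc1cccc(C(=O)/C=C/c2ccc3c(c2)B(O)OC3)c1`, is compound 1 with one change: methoxymethoxy in place of hydrogen on an aromatic carbon. It is not yet measured in this assay.

Within the data shown here, only one measured step bears on this change, the iodo step from compound 1 to compound 2, which put a different group on the same ring of the shared core and left the number essentially where it was. That single step gives no reason to expect a move beyond the scatter in this assay, though the entering group is larger and unlike the iodo group, so the uncertainty is wider than usual. The expected step is therefore a 1.0-fold higher number from compound 1 to compound 3 (0.01 log units; within the scatter), and compound 3 is estimated at 3500 nM, with a range from 1400 nM to 9000 nM.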

Compound 3, half-maximal inhibitory concentration: 11700 nM
Beside the measured number, compound 3's estimate is 3.3-fold (0.52 log units) below it, outside the stated range (above it).
By their numbers in this assay, from the lowest: compounds 1 and 2 (each within the scatter of the next); then compound 3.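

In this assay, methoxymethoxy in place of hydrogen, meta to a large group, gives a 3.4-fold higher number from compound 1 to compound 3 (0.54 log units; beyond the scatter), so compound 3 is a modestly weaker inhibitor than compound 1. Within the data shown here, this is the first change on this aromatic ring to move the number beyond the scatter, whereas the iodo change gave a 1.2-fold higher number from compound 1 to compound 2 (0.09 log units; within the scatter), which stays within it, so this ring does not accept every new group with the number unchanged. Nothing available here accounts for the shift in compound 3.

The two changes differ in both the group that enters and where it sits, so these compounds cannot show whether the group or the place matters more. A hydroxy group, a methoxy group or an amine on the same carbon, or methoxymethoxy elsewhere on this ring, would help separate the two and show whether the shift belongs to methoxymethoxy alone.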